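From compound 2 to compound 3: one further methoxy

The source may hold more compounds than are shown below. What is called first, only, known or untested is meant among the compounds shown, and "the series" means these compounds.

Measured in a functional assay on MIA PaCa-2 cells (Homo sapiens) for cytotoxicity, read by resazurin assay, with a stated time of 72 h; on this read-out higher numbers stand for weaker inhibition and lower numbers for stronger inhibition:
Compound 1 `COc1cc(OC)c(C(=O)/C=C/c2ccccc2)c(OC)c1`: > 20000 nM
Compound 2 `COCOc1cc(OC)cc(OC)c1C(=O)/C=C/c1ccccc1`: 5600 nM

The entry for compound 1, > 20000 nM, is a limit. For the measured compounds named here, compound 2 gives 5600 nM, the only actual number so far in this assay. Compound 3 `COCOc1cc(OC)c(C(=O)/C=C/c2ccccc2)c(OCOC)c1` is reached from compound 2 by methoxy in place of hydrogen on a saturated chain carbon bound to an oxygen on an aromatic ring. Going by the values given here, the one measured step of the same kind is an at least 3.5-fold lower number from compound 1 to compound 2 (0.55 log units; beyond the scatter). A single step is thin support, but it points toward a further modest fall in the number in this assay. The expected size is a 2.2-fold lower number from compound 2 to compound 3 (0.35 log units; beyond the scatter). For compound 3 the estimated value is 2500 nM, with an expected range of 700 nM to 9000 nM.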

Compound 3, half-maximal inhibitory concentration: 2200 nM
The estimate for compound 3 lay 1.1-fold (0.06 log units) above the measured number, and the stated range covers the measured number.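

In this assay the change from methoxy to methoxymethoxy, made a second time, again lowers the number, giving a 2.5-fold lower number from compound 2 to compound 3 (0.41 log units; beyond the scatter) and showing that the first such change does not exhaust the effect. For the compounds shown here, this is the first step of this kind with a real number at both ends, so its size can be read directly. The earlier step gave only a bound, since one of its ends is a limit: the limit of > 20000 nM in this assay, at which 1 of the 3 values shown sits.

The compounds shown leave open whether a free hydroxyl or a longer chain such as ethoxymethoxy would lower the number as well. They also leave open whether the two steps would add up the same way on other cell lines.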